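The compounds below may be only part of what the source reports. "The series", "measured", "known", "first", "only" and "open" are said of these compounds alone.

Compound 1 `O=C1c2cc(COc3ccccc3)nn2CCN1c1cccc(F)c1`: 81%
Compound 2 `O=C1c2cc(COc3ccccc3)nn2CCN1c1ccc(F)c(F)c1`: 81%

In a functional assay on HEK293 cells for positive allosteric modulation of metabotropic glutamate receptor 5 (Homo sapiens), read by calcium flux (a higher number here means a larger maximal response, a lower number a smaller maximal response), compound 1 gives 81%, and compound 2 gives 81%. Among the measured compounds shown here, the one measured step, no change at the digits printed from compound 1 to compound 2 (within the scatter), is a fluoro in place of hydrogen on an aromatic carbon, and it left the maximal response where it was. Compound 2 therefore stands level with compound 1 within the usual scatter of this kind of measurement.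

Compound 3 `O=C1c2cc(COc3ccccc3)nn2CCN1c1ncc(F)cn1` has not yet been measured. It differs from compound 2 in one place: 5-fluoropyrimidin-2-yl in place of 3,4-difluorophenyl on an amide-type nitrogen in a ring. For the measured compounds named here, no measured step exchanges a six-membered aromatic ring of carbon only for one with two hetero atoms at that place on the amide-type nitrogen. Going by the values given here, the only step available, no change at the digits printed from compound 1 to compound 2 (within the scatter), touches a much smaller change and was flat, so it bears only loosely on this one and gives no clear direction. Compound 3 is expected to give about 75% in this assay, within 45% to 100%. The expected step of a number 6 percentage points lower from compound 2 to compound 3 (within the scatter) is thus estimated as small, with a wide range that leaves room for a lower maximal response.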

Compound 3, largest response reached (Emax), in percent of the reference or control that the assay uses: 72%
Estimate against measurement, compound 3: 3 percentage points above, and the stated range covers the measured number.
By their numbers in this assay, from the lowest: compounds 3, 1 and 2 (each within the scatter of the next).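

The first two compounds varied only a fluoro on a phenyl ring, whereas compound 3 replaces the whole 3,4-difluorophenyl group on the amide-type nitrogen with 5-fluoropyrimidin-2-yl. In this assay, this exchange gives a number 9 percentage points lower from compound 2 to compound 3 (within the scatter), and the comparison with the other phenyl compound gives a number 9 percentage points lower from compound 1 to compound 3 (within the scatter). This position therefore accepts a six-membered aromatic ring with 2 hetero atoms and 2 hydrogen-bond acceptors in place of a ring of carbon only with none, with both steps staying within the scatter, although nothing measured here explains this outcome.

The compounds shown leave open whether the maximal response would also hold with a quite different group on this nitrogen, such as a saturated cyclohexyl ring or a plain butyl chain in place of an aromatic ring. They also leave open what the fluorine contributes on the new ring, which a pyrimidin-2-yl group without fluorine, or one carrying a methoxy group at that place, could help to show.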